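This account rests on a few compounds, and the source may have more. Where it says the series, first, only, none or still open, it means among the compounds named here.

Measured so far:
- compound 1, `O=C(/C=C/C=C/c1ccc(OC2CCCC2)cc1)N1CCCCC1`: 16.1%
- compound 2, `O=C(/C=C/C=C/c1ccc(F)cc1)N1CCCCC1`: 48.7%

In an assay for inhibition of Polyunsaturated fatty acid 5-lipoxygenase (Homo sapiens), read by spectrophotometry, tested at 20 uM (on this read-out higher numbers stand for more inhibition at the one concentration tested (going by the name of the read-out) and lower numbers for less inhibition), compound 2 gives the higher of the two numbers; compound 1 sits well under it, as the step of a number 32.6 percentage points higher from compound 1 to compound 2 (beyond the scatter) shows. Compound 3, `O=C(/C=C/C=C/c1ccccc1)N1CCCCC1`, differs from compound 2 by hydrogen in place of fluoro on an aromatic carbon. Going by the values given here, no measured step covers this kind of change: the one known step swaps a cyclopentyloxy for a fluoro, not a fluoro for hydrogen, so it gives only loose guidance. Removing the fluoro is expected to cost a little, giving a downward step of a number 10.7 percentage points lower from compound 2 to compound 3 (beyond the scatter). Compound 3 is therefore estimated at 38%, between 18% and 58%.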

Compound 3, a percentage reported as inhibition, at one concentration (the size of the read-out at that concentration, not a potency): 36.3%
Compound 3: the middle estimate sits 1.7 percentage points above what was measured, within the range that was stated.
By their numbers in this assay, from the lowest: compound 1; then compound 3; then compound 2.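

In this assay, hydrogen gives this position a baseline, and the two substituents move the reading away from it in opposite directions. Replacing fluoro with hydrogen gives a number 12.4 percentage points lower from compound 2 to compound 3 (beyond the scatter), whereas replacing cyclopentyloxy with hydrogen gives a number 20.2 percentage points higher from compound 1 to compound 3 (beyond the scatter), so fluoro adds inhibition relative to hydrogen and cyclopentyloxy takes it away. Nothing available explains this difference. On these data alone, it remains open whether a chlorine atom, a methoxy group or an amine at this position would raise or lower the reading relative to hydrogen.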